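Replacing a Chlorophenyl Group on the Shared Core

This account rests on a few compounds, and the source may have more. Where it says the series, first, only, none or still open, it means among the compounds named here.

compound 1 `COc1cc2nc(Cc3ccccc3Cl)[nH]c(=O)c2cc1OC`: > 10000 nM
compound 2 `COc1cc2nc(-c3ccccc3Cl)nc(N=[N+]=[N-])c2cc1OC`: > 10000 nM

In a functional assay on HCT-116 cells (Homo sapiens) for cytotoxicity, read by MTT assay, with a stated time of 72 h (a lower number here means a stronger inhibitor, a higher number a weaker inhibitor), compound 1 gives > 10000 nM, which is a limit of the assay and not a number. Compound 2 likewise gives > 10000 nM in this assay, again a limit rather than a measured number. For the measured compounds named here, both results sit at the limit of > 10000 nM in this assay, at which 2 of the 2 values shown sit, so compound 2 stands at the edge of what this assay can report, with no measured step separating it from compound 1.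

Compound 3 `COc1cc2nc(-c3cccc(C)c3)nc(N=[N+]=[N-])c2cc1OC` is derived from compound 2 by one change: 3-methylphenyl in place of 2-chlorophenyl on an aromatic carbon. Going by the values given here, no measured pair shows what such an exchange does in this assay, and compound 2 itself offers only a limit. Compound 3 is therefore expected to remain near that limit, with a step from a step that the limit leaves unreadable from compound 2 to compound 3 that is not expected to exceed the scatter. The estimate for compound 3 in this assay is 15000 nM, between 4000 nM and 50000 nM.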

Compound 3, half-maximal inhibitory concentration: > 10000 nM
Compound 3 gave a limit, no number; the forecaster's own chance of this, stated with the estimate: 75%; the middle value does not contradict the limit.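

In this assay compound 3 gives > 10000 nM as a limit of the assay and not a number. For the compounds shown here, no step from compound 2 to compound 3 can be read, as all three results rest at the same limit: the limit of > 10000 nM in this assay, at which 3 of the 3 values shown sit. The compounds shown leave open whether 3-methylphenyl and 2-chlorophenyl differ at all in their effect on these cells.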